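Swapping an aromatic substituent for an octyl chain

The source may report more compounds than this note shows. Statements on the series, on what has been measured and on what is new or still open speak of the compounds shown alone.

Compound 3 `CC(C)(C)c1ccc(-c2cc(-c3cn([C@H]4C[C@H](O)[C@@H](CO)O4)c(=O)[nH]c3=O)on2)cc1` gives the lowest of the three numbers in a functional assay on HCT-15 cells (Homo sapiens) for cytotoxicity, read by sulforhodamine B assay, tested at 10 uM (a higher number here means more inhibition at the concentration tested (going by the name of the read-out), a lower number less inhibition), at 79.8%. Compound 1 `CCCCCc1cc(-c2cn([C@H]3C[C@H](OC(C)=O)[C@@H](COC(C)=O)O3)c(=O)[nH]c2=O)on1` reaches 98.7%, and compound 2 `CC(=O)OC[C@H]1O[C@@H](n2cc(-c3cc(-c4ccccc4)no3)c(=O)[nH]c2=O)C[C@@H]1OC(C)=O` reaches 92.2%; both of these stand beyond the scatter above compound 3. Compound 4 `CCCCCCCCc1cc(-c2cn([C@H]3C[C@H](O)[C@@H](CO)O3)c(=O)[nH]c2=O)on1` differs from compound 3 in one place: octyl in place of 4-(tert-butyl)phenyl on an aromatic carbon. Among the measured compounds shown here, the only measured step that bears on this exchange runs the other way, from an alkyl chain to an aromatic ring: a number 6.5 percentage points lower from compound 1 to compound 2 (within the scatter). That step was small and within the scatter, so the reverse kind of exchange is not expected to move the inhibition much either, though any drift would point upward. For compound 4 the expected value in this assay is 86%, spanning 66% to 99%. This is estimated to amount to a number 6.2 percentage points higher from compound 3 to compound 4 (within the scatter).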

Compound 4, a percentage reported as inhibition, at one concentration (the size of the read-out at that concentration, not a potency): 88.2%
Compound 4: middle estimate off by 2.2 percentage points, on the low side, within the range that was stated.
By their numbers in this assay, from the lowest: compounds 3, 4, 2 and 1 (each within the scatter of the next, the first and the last beyond it).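

In this assay, exchanging 4-(tert-butyl)phenyl for octyl on the aromatic carbon next to the ring nitrogen gives a number 8.4 percentage points higher from compound 3 to compound 4 (within the scatter). Together with a number 6.5 percentage points lower from compound 1 to compound 2 (within the scatter), this makes two exchanges between an aromatic group and an alkyl chain at this position, and both stay within the scatter. Nothing measured here speaks to a cause for this.

The compounds shown leave open how a chain ending in an amine or a carboxylic acid would fare at this position. Going by these compounds, because each value comes from a single concentration, potency also remains open.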